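The source may report more compounds than this note shows. Statements on the series, on what has been measured and on what is new or still open speak of the compounds shown alone.

Measured so far in a physicochemical assay for solubility, read by HPLC, in phosphate buffer, measured as kinetic solubility, with a stated time of 24 h, at 20 degrees C, at pH 7.4, tested at 100 uM; on this read-out lower numbers stand for lower solubility and higher numbers for higher solubility:
compound 1, `Cc1nc(N)nc2c1c(-c1ccc3oc(N)nc3c1)nn2C(C)C`: 74000 nM
compound 2, `CCc1nc(N)nc2c1c(-c1ccc3oc(N)nc3c1)nn2C(C)C`: 62000 nM
compound 3, `CC(C)n1nc(-c2ccc3oc(N)nc3c2)c2c(F)nc(N)nc21`: < 1000 nM, a limit of the assay rather than a number.

Compound 1 and compound 2 lie close together: a 1.2-fold lower number from compound 1 to compound 2 (0.08 log units; within the scatter), for methyl in place of hydrogen on a saturated chain carbon bound to an aromatic carbon. Compound 3 gives only a limit in this assay, see (the limit of < 1000 nM in this assay, at which 1 of the 3 values shown sits). Against both of the numbered compounds the change at the aromatic carbon is large: an at least 74-fold lower number from compound 1 to compound 3 (1.86 log units; beyond the scatter), fluoro in place of methyl on an aromatic carbon, and an at least 62-fold lower number from compound 2 to compound 3 (1.79 log units; beyond the scatter), fluoro in place of ethyl on an aromatic carbon.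

Compound 4, `CC(C)n1nc(-c2ccc3oc(N)nc3c2)c2c(Br)nc(N)nc21`, is not yet measured. It differs from compound 1 by bromo in place of methyl on an aromatic carbon. For the measured compounds named here, the steps that bear on it are the two from compound 1 and compound 2 to compound 3, both large and both toward lower solubility; the step from compound 1 to compound 2, which alters only the chain, is within the scatter and says nothing about a swap of methyl for fluoro or bromo. A large drop in this assay is therefore expected. Compound 4 is estimated at 5000 nM, within 1000 nM to 25000 nM. This corresponds to an expected step of a 15-fold lower number from compound 1 to compound 4 (1.17 log units; beyond the scatter).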

Compound 4, solubility: 4000 nM
For compound 4 the middle estimate is 1.3-fold (0.10 log units) above the measured one, and the stated range covers the measured number.
By their numbers in this assay, from the lowest: compound 4; then compounds 2 and 1 (each within the scatter of the next). At a limit, below all of these: compound 3.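

Bromo on this aromatic carbon, next to the ring nitrogen, also sits far under the alkyl groups in this assay: a 19-fold lower number from compound 1 to compound 4 (1.27 log units; beyond the scatter), and a 16-fold lower number from compound 2 to compound 4 (1.19 log units; beyond the scatter). The large drop seen with fluoro is therefore not confined to that one halogen, and it now rests on a measured number rather than on a limit alone. The two halogens also separate from each other at this position, an at least 4.0-fold higher number from compound 3 to compound 4 (0.60 log units; beyond the scatter), but compound 3 gives a limit, not a number: the limit of < 1000 nM in this assay, at which 1 of the 4 values shown sits.

With only methyl, ethyl, fluoro and bromo at this carbon, the compounds shown do not tell whether chloro, methoxy, an amine or a carboxylic acid would fall with the halogens or stay with the alkyl groups, nor whether a longer chain would keep the numbers of compound 1 and compound 2. As far as these compounds go, the rest of the core is the same in all four compounds, so whether the drop with bromo carries over to a different group elsewhere on the core also stays open.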